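The compounds below may be only part of what the source reports. "The series", "measured", "known", "first", "only" and "open" are said of these compounds alone.

Compound 3, with the structure `COc1cccc(S(=O)(=O)N2CCC(N3CCC(C)CC3)CC2)c1`, sits at the limit of a functional assay on DLD-1 cells (Homo sapiens) for antiproliferative activity, read by CellTiter-Glo, with a stated time of 72 h; on this read-out higher numbers stand for weaker inhibition and lower numbers for stronger inhibition: compound 3 gives > 5000 nM, which is a limit of this assay and not a measured number. Its two measured neighbours lie far below it. Compound 1, `COc1ccccc1-c1cccc(S(=O)(=O)N2CCC(N3CCC(C)CC3)CC2)c1`, gives 21 nM in this assay, and compound 2, `CC1CCN(C2CCN(S(=O)(=O)c3cccc(-c4ccc5ccccc5c4)c3)CC2)CC1`, gives 2 nM. Both of these differ from compound 3 only in the group on the aromatic carbon: the step of an at least 230-fold higher number from compound 1 to compound 3 (2.37 log units; beyond the scatter) and the step of an at least 2500-fold higher number from compound 2 to compound 3 (3.39 log units; beyond the scatter) show that replacing a biaryl group by methoxy loses activity.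

Compound 4, `Cc1ccc(-c2cccc(S(=O)(=O)N3CCC(N4CCC(C)CC4)CC3)c2)cc1`, takes the opposite direction. The change is 4-methylphenyl in place of methoxy on an aromatic carbon, placed on an aromatic carbon of a six-membered aromatic ring of carbon only, meta to a large group. Since the steps from compound 1 and compound 2 to compound 3 were both large and in the direction of weaker inhibition, a large step the other way is expected in this assay, namely an at least 500-fold lower number from compound 3 to compound 4 (2.69 log units; beyond the scatter). Compound 4 is therefore estimated at 10 nM, with a range from 3 nM to 40 nM.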

Compound 4, half-maximal inhibitory concentration: 11 nM
Compound 4: middle estimate off by 1.1-fold (0.04 log units), on the low side, within the range that was stated.
By their numbers in this assay, from the lowest: compound 2; then compounds 4 and 1 (each within the scatter of the next). At a limit, above all of these: compound 3.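

In this assay, 4-methylphenyl joins 2-methoxyphenyl and naphthalen-2-yl as a third aryl group at this place that gives far stronger inhibition than methoxy, with an at least 450-fold lower number from compound 3 to compound 4 (2.65 log units; beyond the scatter). This step has no fixed size, as compound 3 stands at a limit and not at a measured number: the limit of > 5000 nM in this assay, at which 1 of the 4 values shown sits. Among the aryl groups, the two single phenyl rings cannot be told apart, with a 1.9-fold lower number from compound 1 to compound 4 (0.28 log units; within the scatter), whereas naphthalen-2-yl remains distinct from 4-methylphenyl, with a 5.5-fold higher number from compound 2 to compound 4 (0.74 log units; beyond the scatter).

Going by these compounds, it remains open whether an aromatic ring is needed at this place, or whether a cyclohexyl group or a longer alkyl chain could replace it. On these data alone, it is equally open how a pyridyl group or an amine on the added ring would fare in this assay.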